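The source may report more compounds than this note shows. Statements on the series, on what has been measured and on what is new or still open speak of the compounds shown alone.

Measured so far:
compound 1, `O=C(C1CCC2(CCC2)CC1)N1CC(c2nc(-c3cccc(Cl)c3)no2)C1`: > 10000 nM
compound 2, `Cc1ccc(S(=O)(=O)N2CC(c3nc(-c4cccc(Cl)c4)no3)C2)cc1`: 920 nM
compound 3, `O=C(C1CCC(C(F)(F)F)CC1)N1CC(c2nc(-c3cccc(F)c3)no2)C1`: > 10000 nM

All three share the same core and were tested in an assay on HEK293 cells for negative allosteric modulation of metabotropic glutamate receptor 5 (Homo sapiens), read by FLIPR; a higher number here means a weaker inhibitor, a lower number a stronger inhibitor. For compound 1 the result is only a limit of the assay, > 10000 nM, so no number is known for it. Compound 3 likewise stops at a limit, > 10000 nM. Compound 2 is the one of the three with a number, 920 nM. Compound 1 therefore stands at the weak end of what has been measured, at the limit of > 10000 nM in this assay, at which 2 of the 3 values shown sit.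

Compound 4, `CC1CN(C(=O)N2CC(c3nc(-c4cccc(Cl)c4)no3)C2)CC(C)O1`, has not yet been measured. It differs from compound 1 in one place: a group of 8 heavy atoms (6 carbon, 1 nitrogen, 1 oxygen; one six-membered non-aromatic ring with 2 hetero atoms) in place of a group of 9 heavy atoms (9 carbon; one four-membered non-aromatic ring of carbon only, one six-membered non-aromatic ring of carbon only), on a carbonyl carbon. The carbonyl carbon thereby gains a second nitrogen neighbour, from the 2,6-dimethylmorpholin-4-yl group. Among the measured compounds shown here, no measured pair shows a change of this kind, so the size of the step is open. Compound 1 and compound 3 are both amides of rings made only of carbon, and neither gives a number, whereas the sulfonamide compound 2 does. Compound 4 is expected to stay near the weak end, and the step expected here is an at least 1.4-fold lower number from compound 1 to compound 4 (0.15 log units; that floor lies within the scatter). Compound 4 is estimated at 7000 nM, within 1500 nM to 30000 nM.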

Compound 4, half-maximal inhibitory concentration: 990 nM
The estimate for compound 4 lay 7.1-fold (0.85 log units) above the measured number, and the stated range ends above it.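

In this assay, placing 2,6-dimethylmorpholin-4-yl on the carbonyl carbon, where compound 1 carries its two rings of carbon only, gives an at least 10-fold lower number from compound 1 to compound 4 (1.00 log units; beyond the scatter), so this position clearly responds to the group it carries. Compound 4 gives 990 nM and compound 2 gives 920 nM, values within the usual scatter of each other, so a measured number on this core no longer belongs to the sulfonamide alone. The step is only a floor, because compound 1 stands at a limit and not at a number: the limit of > 10000 nM in this assay, at which 2 of the 4 values shown sit.

The change swaps several things at once, since the ring oxygen, the two methyl groups and the second nitrogen on the carbonyl carbon all enter together, and nothing shown separates their shares in the step. A plain morpholin-4-yl group would isolate the methyl groups, and a piperidin-1-yl group, with carbon in place of the ring oxygen, would test whether that oxygen matters or whether the nitrogen on the carbonyl carbon is enough.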